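This account rests on a few compounds, and the source may have more. Where it says the series, first, only, none or still open, it means among the compounds named here.

In a functional assay on A549 cells (Homo sapiens) for antiproliferative activity, read by MTT assay (a higher number here means a weaker inhibitor, a lower number a stronger inhibitor), compound 1 `O=C1NC(c2ccccc2)CN1S(=O)(=O)c1ccc2c(c1)CCCN2` is reported only as a limit, > 20000 nM. Compound 2 `O=C(OCCCl)N1CCCc2cc(S(=O)(=O)N3CC(c4ccccc4)NC3=O)ccc21` is likewise reported only as a limit, > 20000 nM. Within the data shown here, compound 3 `O=C(CCl)NC(=O)N1CCCc2cc(S(=O)(=O)N3CC(c4ccccc4)NC3=O)ccc21` gives 449 nM, the only actual number in this small set. Compound 4 `O=C(NC1CCCCC1)N1CCCc2cc(S(=O)(=O)N3CC(c4ccccc4)NC3=O)ccc21` has not yet been measured. It differs from compound 3 as follows: cyclohexyl in place of (chloromethyl)carbonyl on an amide-type nitrogen. In short, cyclohexyl stands in place of (chloromethyl)carbonyl on an amide-type nitrogen. The step that the two limits leave unreadable from compound 1 to compound 2 offers no guidance. Two large steps do bear on the change, an at least 44-fold lower number from compound 1 to compound 3 (1.64 log units; beyond the scatter) and an at least 44-fold lower number from compound 2 to compound 3 (1.64 log units; beyond the scatter), and both end at the compound carrying the (chloromethyl)carbonyl that compound 4 gives up. Neither step tests a cyclohexyl group, so the size remains uncertain, but a substantial move back towards weaker inhibition is expected, namely a 6.7-fold higher number from compound 3 to compound 4 (0.82 log units; beyond the scatter). Compound 4 is estimated at 3000 nM, with an expected range of 400 nM to 20000 nM.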

Compound 4, half-maximal inhibitory concentration: 231 nM
For compound 4 the middle estimate is 13-fold (1.11 log units) above the measured one; measured number below the stated range.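

In this assay, the (chloromethyl)carbonyl of compound 3 proves not to be needed on the amide-type nitrogen: cyclohexyl, which carries no chlorine and no hydrogen-bond acceptor, takes its place with a 1.9-fold lower number from compound 3 to compound 4 (0.29 log units; within the scatter), so the two compounds stand level. The large gain over the weaker compounds therefore survives this change, at an at least 86-fold lower number from compound 2 to compound 4 (1.93 log units; beyond the scatter) and at an at least 86-fold lower number from compound 1 to compound 4 (1.93 log units; beyond the scatter). Both of these steps are open-ended, as compound 1 and compound 2 are reported only as limits: the limit of > 20000 nM in this assay, at which 2 of the 4 values shown sit.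

As far as these compounds go, what a phenyl ring, a methyl or an amine-bearing chain on this nitrogen would give in this assay remains open. Also open, from the compounds shown here alone, is whether a group much smaller than cyclohexyl would hold the number at this place.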